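From compound 3 to compound 4: a carbamoyl exchange

The source may hold more compounds than are shown below. What is called first, only, known or untested is meant among the compounds shown, and "the series" means these compounds.

In a functional assay on KB cells (Homo sapiens) for antiproliferative activity, read by sulforhodamine B assay, with a stated time of 3 days (a higher number here means a weaker inhibitor of growth, a lower number a stronger inhibitor of growth), compound 1 `O=C(Nc1ccccn1)c1cccc(Nc2ncc(F)c(Nc3ccc(F)cc3)n2)c1` gives 20000 nM, and compound 2 `O=C(Nc1cccc(Nc2ncc(F)c(Nc3ccc(F)cc3)n2)c1)c1cnccn1` gives 23600 nM. These two do not separate: a 1.2-fold higher number from compound 1 to compound 2 (0.07 log units; within the scatter). Compound 3 `O=C(Nc1cccc(Nc2ncc(F)c(Nc3ccc(F)cc3)n2)c1)c1ccncc1` has the lowest number of the three, at 5280 nM, and it stands clear of both: a 3.8-fold lower number from compound 1 to compound 3 (0.58 log units; beyond the scatter), and a 4.5-fold lower number from compound 2 to compound 3 (0.65 log units; beyond the scatter).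

Compound 4 `Cn1ccnc1NC(=O)c1cccc(Nc2ncc(F)c(Nc3ccc(F)cc3)n2)c1` has (1-methyl-1H-imidazol-2-yl)carbamoyl in place of ((pyridin-4-yl)carbonyl)amino on an aromatic carbon. Its carbamoyl link matches that of compound 1, which carries (pyridin-2-yl)carbamoyl and gives 20000 nM, so that compound is the closest guide. Among the measured compounds shown here, no measured compound carries a five-membered ring, so the ring itself remains an open question. A modest rise is therefore expected, in the opposite direction to the step towards compound 3 and of similar size. The expected change is a 2.8-fold higher number from compound 3 to compound 4 (0.45 log units; beyond the scatter). For compound 4 the estimate is 15000 nM, with an expected range of 5500 nM to 40000 nM.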

Compound 4, concentration for 50% growth inhibition: 14600 nM
For compound 4 the middle estimate is 1.0-fold (0.01 log units) above the measured one; low and high end bracket the measured number.
By their numbers in this assay, from the lowest: compound 3; then compounds 4, 1 and 2 (each within the scatter of the next).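

In this assay, the five-membered ring does not separate from the six-membered ring on the carbamoyl link (a 1.4-fold lower number from compound 1 to compound 4 (0.14 log units; within the scatter)), so 1-methyl-1H-imidazol-2-yl and pyridin-2-yl read alike on the amide-type nitrogen. Compound 4 also does not separate from the compound carrying ((pyrazin-2-yl)carbonyl)amino (a 1.6-fold lower number from compound 2 to compound 4 (0.21 log units; within the scatter)), while the exchange for ((pyridin-4-yl)carbonyl)amino gives a step beyond the scatter (a 2.8-fold higher number from compound 3 to compound 4 (0.44 log units; beyond the scatter)), which leaves compound 3 alone with the lowest of the four numbers. Nothing available gives a reason for any of these steps.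

The compounds shown leave open whether the direction of the amide link or the ring attached to it sets the step to compound 3, a question that a pyridin-4-yl carbamoyl would address. Also open, as far as these compounds go, is how a morpholine or a carboxylic acid on the terminal ring would read.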